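The compounds below may be only part of what the source reports. "The series", "measured", "known", "first", "only" and "open" are said of these compounds alone.

Compound 1 `C/C(=C\C(=O)Nc1ccccc1OCCCC(=O)O)c1ccc2c(ccn2C)c1`: 780 nM
Compound 2 `CCCCn1ccc2cc(/C(C)=C/C(=O)Nc3ccccc3OCCCC(=O)O)ccc21`: 43 nM
Compound 3 `CCCCCCCn1ccc2cc(/C(C)=C/C(=O)Nc3ccccc3OCCCC(=O)O)ccc21`: 120 nM

These three share a core and differ only in the chain on the aromatic nitrogen, measured in an assay on Prostate gland for inhibition of steroid 5-alpha-reductase (Rattus norvegicus); a lower number here means a stronger inhibitor, a higher number a weaker inhibitor. Compound 3 sits second highest of the three numbers: a 2.8-fold higher number from compound 2 to compound 3 (0.45 log units; beyond the scatter), while a 6.5-fold lower number from compound 1 to compound 3 (0.81 log units; beyond the scatter). Compound 4 `CCC(C)n1ccc2cc(/C(C)=C/C(=O)Nc3ccccc3OCCCC(=O)O)ccc21` carries sec-butyl in place of heptyl on an aromatic nitrogen. The step from compound 1 to compound 2, an 18-fold lower number from compound 1 to compound 2 (1.26 log units; beyond the scatter), and the step from compound 2 to compound 3 bear on this change, since compound 4 returns to a four-carbon chain like compound 2. Compound 4 is therefore expected to land a modest step below compound 3, a 2.0-fold lower number from compound 3 to compound 4 (0.30 log units; within the scatter), at an estimated 60 nM with a range of 25 nM to 150 nM.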

Compound 4, half-maximal inhibitory concentration: 67 nM
The estimate for compound 4 lay 1.1-fold (0.05 log units) below the measured number; measured number inside the range.
By their numbers in this assay, from the lowest: compounds 2, 4 and 3 (each within the scatter of the next, the first and the last beyond it); then compound 1.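

In this assay, putting sec-butyl on the aromatic nitrogen gives a 1.8-fold lower number from compound 3 to compound 4 (0.25 log units; within the scatter) and a 1.6-fold higher number from compound 2 to compound 4 (0.19 log units; within the scatter), so compound 4 cannot be told apart from either straight-chain compound, and the branched chain reads the same as butyl. Against methyl, the result is a 12-fold lower number from compound 1 to compound 4 (1.07 log units; beyond the scatter), which shows that the gain over compound 1 also holds for a branched chain. Nothing given here explains these steps. The compounds shown leave open whether a cyclohexyl or benzyl group on this nitrogen would give a similar number, and whether an amine at the end of the chain would.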